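Pyrimidine-carboxylate NF-kappa-B series: compound 3 from compound 1

This account rests on a few compounds, and the source may have more. Where it says the series, first, only, none or still open, it means among the compounds named here.

Measured compounds:
- compound 1 `CCOC(=O)c1cnc(-c2cnc3ccccc3c2)nc1NN1C(=O)C=C(C)C1=O`: 6000 nM
- compound 2 `CCOC(=O)c1cnc(C(=O)c2ccco2)nc1NN1C(=O)C=C(C)C1=O`: 700 nM

In a functional assay on Jurkat cells for inhibition of nuclear factor NF-kappa-B complex (Homo sapiens) (on this read-out higher numbers stand for weaker inhibition and lower numbers for stronger inhibition), compound 1 gives 6000 nM and stands highest of the two numbers; the nearest is compound 2 at 700 nM, which lies beyond the scatter from compound 1. Compound 3 `CCOC(=O)c1cnc(Cc2ccccc2)nc1NN1C(=O)C=C(C)C1=O` is not yet measured. It differs from compound 1 in one place: benzyl in place of quinolin-3-yl on an aromatic carbon. Within the data shown here, the only measured step that touches the same position is an 8.6-fold lower number from compound 1 to compound 2 (0.93 log units; beyond the scatter), where the quinolin-3-yl group was exchanged for a (furan-2-yl)carbonyl group and the number fell by a modest amount. That step shows that replacing quinolin-3-yl on this aromatic carbon can move the number downward, but benzyl is not the group that entered there, so the size of the step is uncertain; a downward move of similar or smaller size, or none beyond the scatter, is plausible. On this basis compound 3 is expected to give 3000 nM in this assay, within 800 nM to 12000 nM, which would mean an estimated step of a 2.0-fold lower number from compound 1 to compound 3 (0.30 log units; within the scatter).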

Compound 3, half-maximal inhibitory concentration: 7000 nM
Estimate against measurement, compound 3: 2.3-fold (0.37 log units) below; measured number inside the range.
By their numbers in this assay, from the lowest: compound 2; then compounds 1 and 3 (each within the scatter of the next).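

In this assay, benzyl in place of quinolin-3-yl gives a 1.2-fold higher number from compound 1 to compound 3 (0.07 log units; within the scatter), so this read-out does not separate the two groups, although benzyl lacks the ring with a hetero atom and the hydrogen-bond acceptor counted for quinolin-3-yl. Against this, (furan-2-yl)carbonyl now stands apart from a second group: the change to benzyl gives a 10-fold higher number from compound 2 to compound 3 (1.00 log units; beyond the scatter), which shows that the earlier fall at this aromatic carbon did not come with just any replacement of quinolin-3-yl, and places compound 2 alone at the low end among these three compounds. Nothing available here bears on what sets (furan-2-yl)carbonyl apart from the other two groups.

The compounds shown do not separate the carbonyl from the furan-2-yl ring, as the two enter together in compound 2, and a benzoyl group or a directly attached furan-2-yl group on this carbon would bear on that question. On these data alone, how an amine or a carboxylic acid would read on this same carbon also remains open.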